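The source may report more compounds than this note shows. Statements on the series, on what has been measured and on what is new or still open speak of the compounds shown alone.

The measured compounds:
compound 1 `CC(C)=CCc1cc(C(=O)Nc2cc3ccc(OCC4CCCNC4)c(C)c3oc2=O)ccc1O`: 790 nM
compound 2 `CCCN(CCC)CCCOc1ccc2cc(NC(=O)c3ccc(O)c(CC=C(C)C)c3)c(=O)oc2c1C`: > 50000 nM
compound 3 `CC(C)=CCc1cc(C(=O)Nc2cc3ccc(OCCCNC(C)C)c(C)c3oc2=O)ccc1O`: 740 nM

In a functional assay on MCF7 cells (Homo sapiens) for antiproliferative activity (a higher number here means a weaker inhibitor, a lower number a stronger inhibitor), compound 1 gives 790 nM. Its nearest neighbour is compound 3 with 740 nM, and a 1.1-fold lower number from compound 1 to compound 3 (0.03 log units; within the scatter), so the two numbers cannot be ordered. For the measured compounds named here, for compound 2 the assay returns only a limit, > 50000 nM, and no number; it is the only other value reported.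

Compound 4 `CC(C)=CCc1cc(C(=O)Nc2cc3ccc(OCCCN(C(C)C)C(C)C)c(C)c3oc2=O)ccc1O` is not yet measured. It differs from compound 1 in one place: 2-(diisopropylamino)ethyl in place of piperidin-3-yl on a saturated chain carbon bound to an oxygen on an aromatic ring.

Going by the values given here, two measured steps bear on this change, each replacing the piperidin-3-yl by an open chain ending in an amine. Where the chain ends in dipropylamino, the result was an at least 63-fold higher number from compound 1 to compound 2 (1.80 log units; beyond the scatter), reaching (the limit of > 50000 nM in this assay, at which 1 of the 3 values shown sits). Where it ends in isopropylamino, the result was a 1.1-fold lower number from compound 1 to compound 3 (0.03 log units; within the scatter); between those two chain ends, an at least 67-fold lower number from compound 2 to compound 3 (1.82 log units; beyond the scatter). The diisopropylamino end of compound 4 resembles dipropylamino rather than isopropylamino, so a large step toward weaker inhibition is expected in this assay: a 38-fold higher number from compound 1 to compound 4 (1.58 log units; beyond the scatter). Compound 4 is therefore estimated at 30000 nM, in a range from 3000 nM to 100000 nM, with a fair chance that only a limit is returned.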

Compound 4, half-maximal inhibitory concentration: 1310 nM
Beside the measured number, compound 4's estimate is 23-fold (1.36 log units) above it, and the stated range ends above it.
By their numbers in this assay, from the lowest: compounds 3, 1 and 4 (each within the scatter of the next). At a limit, above all of these: compound 2.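

In this assay, the open chain ending in diisopropylamino can take the place of piperidin-3-yl with no readable loss, a 1.7-fold higher number from compound 1 to compound 4 (0.22 log units; within the scatter), and isopropyl in place of hydrogen on the amine nitrogen also stays unresolved, a 1.8-fold higher number from compound 3 to compound 4 (0.25 log units; within the scatter). A chain end with no hydrogen on its nitrogen therefore does not by itself set compound 2 apart, and the large difference among these compounds follows the exchange of dipropylamino for diisopropylamino, an at least 38-fold lower number from compound 2 to compound 4 (1.58 log units; beyond the scatter). For compound 2 the assay gives a limit and not a number: the limit of > 50000 nM in this assay, at which 1 of the 4 values shown sits.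

The compounds shown leave open whether the loss is peculiar to dipropylamino or would also appear with other chain ends, such as diethylamino, a pyrrolidine or a morpholine. They also do not tell how a shorter or longer chain carrying the amine, or a chain ending in a hydroxyl or a carboxylic acid in place of any amine, would read in this assay.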